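Methoxy for Methyl on the Benzyl Group of Compound 2

The source may report more compounds than this note shows. Statements on the series, on what has been measured and on what is new or still open speak of the compounds shown alone.

For the measured compounds named here, compound 2 `COc1cccc(OC)c1OCCNCCOc1ccccc1OCc1ccc(C)cc1` gives 0.251 nM in an assay on CHO cells for displacement of a labelled ligand from Alpha-1B adrenergic receptor (Homo sapiens) (on this read-out higher numbers stand for weaker inhibition and lower numbers for stronger inhibition), the lowest of the three numbers so far. Compound 1 `COc1cccc(OC)c1OCCNCCOc1ccccc1OCc1ccccc1Cl` gives 0.562 nM, and compound 3 `COc1cccc(OC)c1OCCNCCOc1ccccc1OCc1ccccc1[N+](=O)[O-]` gives 2.51 nM. The pendant aryl group moves the read-out: a 2.2-fold lower number from compound 1 to compound 2 (0.35 log units; beyond the scatter); a 10-fold higher number from compound 2 to compound 3 (1.00 log units; beyond the scatter); a 4.5-fold higher number from compound 1 to compound 3 (0.65 log units; beyond the scatter). Compound 4 `COc1ccc(COc2ccccc2OCCNCCOc2c(OC)cccc2OC)cc1` carries methoxy in place of methyl on an aromatic carbon. Going by the values given here, no measured step exchanges these two groups; the three steps above show only that this part of the molecule shifts the number by modest amounts. A small step is therefore expected, a 1.4-fold higher number from compound 2 to compound 4 (0.14 log units; within the scatter), not clearly beyond the scatter in either direction. Compound 4 is estimated at 0.35 nM, with a range from 0.12 nM to 1 nM.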

Compound 4, inhibition constant: 0.398 nM
Estimate against measurement, compound 4: 1.1-fold (0.06 log units) below; low and high end bracket the measured number.
By their numbers in this assay, from the lowest: compounds 2, 4 and 1 (each within the scatter of the next, the first and the last beyond it); then compound 3.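

In this assay, methoxy in place of methyl on the aromatic carbon para to a large group leaves the read-out within the scatter: a 1.6-fold higher number from compound 2 to compound 4 (0.20 log units; within the scatter). The 4-methoxyphenyl group also stays within the scatter of 2-chlorophenyl, with a 1.4-fold lower number from compound 1 to compound 4 (0.15 log units; within the scatter), whereas 2-nitrophenyl remains apart, with a 6.3-fold lower number from compound 3 to compound 4 (0.80 log units; beyond the scatter). Nothing available explains these steps.

Open, on these data alone, is whether a hydroxyl, an amine or a carboxylic acid on this same carbon would stay within the scatter. Also open, as far as these compounds go, is how methoxy behaves on another carbon of this ring.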